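This account rests on a few compounds, and the source may have more. Where it says the series, first, only, none or still open, it means among the compounds named here.

Compound 1, `C/C(=C\CC/C(C)=C/CC[C@@H]1[C@@]2(C)CCC(=O)C(C)(C)[C@H]2CC[C@@]1(C)O)CC/C=C(\C)C(=O)OCc1cn(-c2ccccc2[N+](=O)[O-])nn1`: > 150000 nM
Compound 2, `C/C(=C\CC/C(C)=C/CC[C@@H]1[C@@]2(C)CCC(=O)C(C)(C)[C@H]2CC[C@@]1(C)O)CC/C=C(\C)C(=O)OCc1cn(-c2ccc(Br)cc2)nn1`: > 150000 nM
Compound 3, `C/C(=C\CC/C(C)=C/CC[C@@H]1[C@@]2(C)CCC(=O)C(C)(C)[C@H]2CC[C@@]1(C)O)CC/C=C(\C)C(=O)OCc1cn(-c2ccc(C)cc2)nn1`: > 150000 nM

In an ADME assay on L132 cells (Homo sapiens) for cytotoxicity, read by MTT assay, with a stated time of 48 h (on this read-out lower numbers stand for stronger inhibition and higher numbers for weaker inhibition), compound 1 gives > 150000 nM, which is a limit of the assay rather than a number. Compound 2 likewise gives only a limit, > 150000 nM. Compound 3 also gives only a limit, > 150000 nM. All three values therefore sit at the limit of > 150000 nM in this assay, at which 3 of the 3 values shown sit. Compound 4, `C/C(=C\CC/C(C)=C/CC[C@@H]1[C@@]2(C)CCC(=O)C(C)(C)[C@H]2CC[C@@]1(C)O)CC/C=C(\C)C(=O)OCc1cn(-c2cccc(O)c2)nn1`, is not yet measured; it differs from compound 1 by 3-hydroxyphenyl in place of 2-nitrophenyl on an aromatic nitrogen. The measured steps that touch the same group on the aromatic nitrogen, a step that the two limits leave unreadable from compound 1 to compound 2 and a step that the two limits leave unreadable from compound 1 to compound 3, cannot be read in size. Nothing here points to a step beyond the scatter in this assay. Compound 4 is expected to give about 200000 nM, between 100000 nM and 400000 nM, most likely again as a limit. The expected step is a step that the limit leaves unreadable from compound 1 to compound 4.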

Compound 4, half-maximal inhibitory concentration: 146000 nM
Compound 4: middle estimate off by 1.4-fold (0.14 log units), on the high side; low and high end bracket the measured number.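

In this assay, among these compounds, compound 4, with 3-hydroxyphenyl on the aromatic nitrogen, gives a number, 146000 nM, not a limit, which none of the earlier compounds did. Set against those limits, this reads as an at least 1.0-fold lower number from compound 1 to compound 4 (0.01 log units; that floor lies within the scatter), an at least 1.0-fold lower number from compound 3 to compound 4 (0.01 log units; that floor lies within the scatter) and an at least 1.0-fold lower number from compound 2 to compound 4 (0.01 log units; that floor lies within the scatter), so no change beyond the scatter is shown, and the steps among compound 1, compound 2 and compound 3 cannot be read. The values stay together at one end of the assay: the limit of > 150000 nM in this assay, at which 3 of the 4 values shown sit.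

On these data alone, it remains open whether an amine or a carboxylic acid on the phenyl ring would give a step beyond the scatter. As far as these compounds go, it also remains open what a longer chain in place of the phenyl ring would give.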